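The source may hold more compounds than are shown below. What is called first, only, known or untested is meant among the compounds shown, and "the series" means these compounds.

Measured compounds:
Compound 1 `COc1cccc(OC)c1OCCNCCOc1ccccc1OCc1ccccc1C` — in a functional assay on thoracic aorta for antagonist activity at Alpha-1D adrenergic receptor (Rattus norvegicus) (on this read-out higher numbers stand for higher potency (the scale is a negative logarithm) and lower numbers for lower potency), compound 1 gives 8.64.
Compound 2 `COc1cccc(OC)c1OCCNCCOc1ccccc1OCc1ccccc1[N+](=O)[O-]` — in this assay compound 2 gives 8.95.

Of these two numbers, compound 1 has the lower one; compound 2 sits a number 0.31 log units higher from compound 1 to compound 2 (beyond the scatter).

Compound 3 `COc1ccc(COc2ccccc2OCCNCCOc2c(OC)cccc2OC)cc1` has not yet been measured. It differs from compound 1 at one place: 4-methoxyphenyl in place of 2-methylphenyl on a saturated chain carbon bound to an oxygen on an aromatic ring. In other words, the (2-methylbenzyl)oxy group becomes a (4-methoxybenzyl)oxy group.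

Among the measured compounds shown here, the one known step, a number 0.31 log units higher from compound 1 to compound 2 (beyond the scatter), also changes a group on that same outer ring, but it swaps a different group at a different place, so it bears on compound 3 only loosely. What it does show is that changes on this ring moved the read-out only modestly. A similarly small shift, in either direction or none beyond the scatter, is therefore expected for compound 3; the estimated step is a number 0.04 log units lower from compound 1 to compound 3 (within the scatter). Compound 3 is estimated at 8.6, with a likely range from 8.1 to 9.1.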

Compound 3, negative logarithm of the antagonist equilibrium constant: 9.21
The estimate for compound 3 lay 0.61 log units below the measured number; the whole stated range lies below it.
By their numbers in this assay, from the lowest: compound 1; then compounds 2 and 3 (each within the scatter of the next).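

In this assay, replacing 2-methylphenyl with 4-methoxyphenyl gives a number 0.57 log units higher from compound 1 to compound 3 (beyond the scatter) and shows that this position accepts a change in both the group on the outer ring and the number of its place, without any loss in the read-out. The other replacement, 2-nitrophenyl, cannot be told apart from 4-methoxyphenyl, with a number 0.26 log units higher from compound 2 to compound 3 (within the scatter) and so two quite different groups both stand clear of the 2-methylphenyl compound, which makes compound 1 the lowest of the three. Nothing measured here explains why the read-out moves.

The compounds shown cannot separate the effect of the methoxy group from that of its place on the ring. A 2-methoxyphenyl or a 4-methylphenyl group would divide those two changes, and plain phenyl would show what the unsubstituted ring gives.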